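Hydroxy in Place of 5-Hydroxypentyl: An Expected Step

The source may hold more compounds than are shown below. What is called first, only, known or untested is meant among the compounds shown, and "the series" means these compounds.

In a functional assay on MCF7 cells (Homo sapiens) (a higher number here means a weaker inhibitor, a lower number a stronger inhibitor), compound 1 `COc1cc(NC(C)CCCNC(=O)NCCCCCO)c2ncccc2c1` gives 44000 nM and compound 2 `COc1cc(NC(C)CCCNC(=O)NCCNC(=O)NCCCC(C)Nc2cc(OC)cc3cccnc23)c2ncccc2c1` gives 31000 nM, two values within the usual scatter of each other. Compound 3 `COc1cc(NC(C)CCCNC(=O)NO)c2ncccc2c1` differs from compound 1 by carrying hydroxy in place of 5-hydroxypentyl on an amide-type nitrogen. For the measured compounds named here, no measured pair shows what such a change does, so only a modest move toward a lower number is expected, and the range also allows for no change beyond the scatter. The expected step is a 2.2-fold lower number from compound 1 to compound 3 (0.34 log units; beyond the scatter). For compound 3, the estimated value is 20000 nM, within an expected range of 6000 nM to 60000 nM.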

Compound 3, half-maximal inhibitory concentration: 44000 nM
Compound 3: the middle estimate sits 2.2-fold (0.34 log units) below what was measured, and the stated range covers the measured number.
By their numbers in this assay, from the lowest: compounds 2, 1 and 3 (each within the scatter of the next).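

Putting hydroxy in place of 5-hydroxypentyl on the amide-type nitrogen gives no change at the digits printed from compound 1 to compound 3 (within the scatter) in this assay. For the compounds shown here, this pair gives the first reading at this position: in this assay, the carbon chain of 5-hydroxypentyl can go, with hydroxy left on the nitrogen, without any shift in the number. Nothing at hand explains this result. Going by these compounds, whether an amine, a carboxylic acid or a longer chain on this nitrogen would move the number remains open. So does whether a plain methyl group would match hydroxy here.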